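Series notes: benzyl for cyclohexyl on the imidazole nitrogen

The compounds below may be only part of what the source reports. "The series", "measured", "known", "first", "only" and "open" are said of these compounds alone.

Values measured in a functional assay on KM12 cells (Homo sapiens) for inhibition, read by sulforhodamine B assay, with a stated time of 48 h, tested at 10 uM; on this read-out higher numbers stand for more inhibition at the one concentration tested (going by the name of the read-out) and lower numbers for less inhibition:
compound 1 `c1ccc2c(-c3cn4ccnc4c(-c4ccc5ncn(C6CCCCC6)c5c4)n3)cccc2c1` — 11.1%
compound 2 `Fc1ccc(-c2cn3ccnc3c(-c3ccc4ncn(C5CCCCC5)c4c3)n2)cc1` — 3.49%
compound 3 `Fc1ccccc1-c1cn2ccnc2c(-c2ccc3ncn(C4CCCCC4)c3c2)n1` — 2.45%

Compound 1 gives the top number of the three, but its gaps to the other two, a number 7.6 percentage points lower from compound 1 to compound 2 (within the scatter) and a number 8.7 percentage points lower from compound 1 to compound 3 (within the scatter), both fall within the scatter, so the three compounds are not separable in this assay. The remaining measured step, a number 1 percentage points lower from compound 2 to compound 3 (within the scatter), is likewise within the scatter. All three measured steps exchange the aryl group on an aromatic carbon of the shared core; none of them touches the group on the aromatic nitrogen.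

Compound 4 `c1ccc(Cn2cnc3ccc(-c4nc(-c5cccc6ccccc56)cn5ccnc45)cc32)cc1` differs from compound 1 by benzyl in place of cyclohexyl on an aromatic nitrogen. For the measured compounds named here, no measured step bears on this position, so nothing in the present numbers speaks for a change beyond the scatter in either direction. Going by the values given here, the three measured steps, each within the scatter, show a series in which the numbers so far stay low whatever the aryl change, and the only anchor for compound 4 is compound 1 at 11.1%.

Compound 4 is therefore expected to give 10% in this assay, within 0% to 30%, an expected step of a number 1.1 percentage points lower from compound 1 to compound 4 (within the scatter), that is, none beyond the scatter.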

Compound 4, a percentage reported as inhibition, at one concentration (the size of the read-out at that concentration, not a potency): 11%
Estimate against measurement, compound 4: 1 percentage points below, and the stated range covers the measured number.
By their numbers in this assay, from the lowest: compounds 3, 2, 4 and 1 (each within the scatter of the next).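

The aromatic nitrogen of the five-membered ring now has its first measured step: in this assay, a number 0.1 percentage points lower from compound 1 to compound 4 (within the scatter), with benzyl in place of cyclohexyl. For the compounds shown here, with naphthalen-1-yl held on the aromatic carbon, a non-aromatic carbon ring and an aromatic one at this nitrogen cannot be told apart by this read-out, whereas the earlier steps exchanged only the aryl group and left this position untested. No separate measurement bears on the reason for this result.

The compounds shown leave open whether an amine or a carboxylic acid on the benzyl ring, or a longer chain such as phenethyl on the aromatic nitrogen, would give a number beyond the scatter. They also leave open whether benzyl would read the same with 4-fluorophenyl or 2-fluorophenyl in place of naphthalen-1-yl, and, with a single tested concentration, what potency any of these four compounds has.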